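Swapping the Aryl Ether Group: From Compound 3 to Compound 4

The source may hold more compounds than are shown below. What is called first, only, known or untested is meant among the compounds shown, and "the series" means these compounds.

Three compounds built on a shared core differ only in the aromatic group joined through an oxygen on a saturated carbon. Compound 1 `O=C(O)c1csc([C@H]2CC[C@@H]3[C@@H](COc4ccc(C(F)(F)F)cc4)[C@H](O)C[C@@H]3O2)n1` carries a 4-(trifluoromethyl)phenyl group, and in a functional assay on CHO cells for agonist activity at prostaglandin E2 receptor EP2 subtype (Homo sapiens), read by HTRF and cAMP accumulation, with a stated time of 30 min (on this read-out higher numbers stand for an effect only at larger amounts of compound and lower numbers for an effect already at smaller amounts), compound 1 gives 13 nM. Compound 2 `O=C(O)c1csc([C@H]2CC[C@@H]3[C@@H](COc4ccccc4F)[C@H](O)C[C@@H]3O2)n1` carries a 2-fluorophenyl group; in this assay compound 2 gives 23 nM. Compound 3 `Cc1cccc(OC[C@@H]2[C@H]3CC[C@H](c4nc(C(=O)O)cs4)O[C@H]3C[C@H]2O)c1` carries a 3-methylphenyl group, and in this assay compound 3 gives 3.6 nM, the lowest of the three numbers and beyond the scatter from both of the others. The steps leading to it were a 3.6-fold lower number from compound 1 to compound 3 (0.56 log units; beyond the scatter) and a 6.4-fold lower number from compound 2 to compound 3 (0.81 log units; beyond the scatter). Compound 4 `O=C(O)c1csc([C@H]2CC[C@@H]3[C@@H](COc4ccccc4C(F)(F)F)[C@H](O)C[C@@H]3O2)n1` is reached from compound 3 by the change (2-(trifluoromethyl)phenyl in place of 3-methylphenyl on an oxygen on a saturated carbon). This move leaves the 3-methylphenyl group behind, and both measured steps toward that group lowered the number by a modest amount, so a modest rise is expected on going the other way. The step from compound 3 to compound 4 is estimated at a 5.0-fold higher number from compound 3 to compound 4 (0.70 log units; beyond the scatter) in this assay. Compound 4 is expected to give 18 nM, within a range of 6 nM to 50 nM.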

Compound 4, half-maximal effective concentration: 0.5 nM
For compound 4 the middle estimate is 36-fold (1.56 log units) above the measured one, outside the stated range (below it).
By their numbers in this assay, from the lowest: compound 4; then compound 3; then compounds 1 and 2 (each within the scatter of the next).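

In this assay, the result shows that this position is sensitive to where the trifluoromethyl group sits on the phenyl ring: moving from the 4-(trifluoromethyl)phenyl to the 2-(trifluoromethyl)phenyl group gives a 26-fold lower number from compound 1 to compound 4 (1.41 log units; beyond the scatter). The group on the same ring matters too, as trifluoromethyl in place of fluoro on an aromatic carbon gives a 46-fold lower number from compound 2 to compound 4 (1.66 log units; beyond the scatter). The earlier compounds shown here had pointed to the 3-methylphenyl group as the most favourable of those tried, yet the new group goes further, with a 7.2-fold lower number from compound 3 to compound 4 (0.86 log units; beyond the scatter).

Nothing in the material shown explains why this group lowers the number so far. From the compounds shown here alone, it also remains open whether a 2-chlorophenyl or 2-methoxyphenyl group on the same oxygen would give a number as low.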